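The source may hold more compounds than are shown below. What is called first, only, known or untested is meant among the compounds shown, and "the series" means these compounds.

In a functional assay (aorta) with Oryctolagus cuniculus as the target (a higher number here means a weaker inhibitor, a lower number a stronger inhibitor), two compounds have been measured. Compound 1 `OCc1ccc(-c2nn(Cc3ccccc3F)c3cccnc23)o1` gives 20400 nM. Compound 2 `CCCc1cnc(-c2nn(Cc3ccccc3F)c3ncccc23)nc1N` gives 252000 nM, the higher of the two numbers, and its gap to compound 1 lies beyond the usual scatter of repeated measurements. Within the data shown here, no step between a pair of compounds differing in a single place has been recorded, so the two values show only that compound 2 is the weaker of the two in this assay, without telling which part of the structure carries the difference.

Compound 3 `NCc1cnc(-c2nn(Cc3ccccc3F)c3ncccc23)nc1N` has not yet been measured. Its structure differs from compound 2 in one place: amino in place of ethyl on a saturated chain carbon bound to an aromatic carbon. Read one bond further out, the propyl of compound 2 becomes an aminomethyl in compound 3.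

Among the measured compounds shown here, with no measured step of this kind on record, the expectation rests only on the value of compound 2. The step from compound 2 to compound 3 is expected to be a 1.7-fold lower number from compound 2 to compound 3 (0.23 log units; within the scatter) in this assay, probably toward a lower number but not certainly beyond the scatter. Compound 3 is expected to give about 150000 nM, within a range from 30000 nM to 600000 nM.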

Compound 3, half-maximal inhibitory concentration: 1400000 nM
Estimate against measurement, compound 3: 9.3-fold (0.97 log units) below; measured number above the stated range.
By their numbers in this assay, from the lowest: compound 1; then compound 2; then compound 3.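

In this assay, among these compounds, amino in place of ethyl on a saturated chain carbon bound to an aromatic carbon brings a 5.6-fold higher number from compound 2 to compound 3 (0.74 log units; beyond the scatter), the only step on record between compounds differing in one place. The earlier values could only rank two compounds differing in more than one place, whereas this step shows that a change at this position alone, with the rest of the structure held, moves the number beyond the scatter and toward a weaker inhibitor. No measurement at hand offers an explanation for this step.

From the compounds shown here alone, a single step cannot separate the loss of the ethyl from the arrival of the amino, so it remains open where a hydroxyl, a carboxylic acid or a longer chain at this place would fall relative to the propyl and the aminomethyl. Also open, going by these compounds, is whether the same exchange would shift the number in the same direction and to a similar extent on a different core, such as the core of compound 1.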